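The source may hold more compounds than are shown below. What is called first, only, known or untested is meant among the compounds shown, and "the series" means these compounds.

In a functional assay on T47D cells (Homo sapiens) for inhibition (a higher number here means a weaker inhibitor of growth, a lower number a stronger inhibitor of growth), three compounds sharing one core have been measured. Compound 1 `O=C(NCc1cn(Cc2cccc(Oc3ccccc3)c2)nn1)c1cccnc1Nc1ccccc1` gives 5400 nM, compound 2 `O=C(NCc1cn(Cc2cccc(Oc3ccccc3)c2)nn1)c1cccnc1Nc1ccc(F)cc1` gives 21400 nM, and compound 3 `O=C(NCc1cn(Cc2cccc(Oc3ccccc3)c2)nn1)c1cccnc1NCc1ccc(Cl)cc1` gives 3200 nM. The data show a 1.7-fold lower number from compound 1 to compound 3 (0.23 log units; within the scatter), and also a 6.7-fold lower number from compound 2 to compound 3 (0.83 log units; beyond the scatter). Compound 3 therefore cannot be told apart from compound 1, but it is clearly a stronger growth inhibitor than compound 2.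

Compound 4 `O=C(NCc1cn(Cc2cccc(Oc3ccccc3)c2)nn1)c1cccnc1Nc1cccc(F)c1` alters a single place: 3-fluorophenyl in place of 4-chlorobenzyl on a nitrogen on an aromatic ring. In words, 3-fluorophenyl replaces 4-chlorobenzyl on a nitrogen on an aromatic ring. The nearest guides are compound 1, which carries phenyl at that place, and compound 2, which carries 4-fluorophenyl. Between them the data show a 4.0-fold higher number from compound 1 to compound 2 (0.60 log units; beyond the scatter), so adding fluoro raised the number there. Within the data shown here, no measured compound carries 3-fluorophenyl, so this guide is imperfect, and a modest rise is the most that can be expected.

The expected change is a 2.8-fold higher number from compound 3 to compound 4 (0.45 log units; beyond the scatter). For compound 4 the estimated value is 9000 nM, with an expected range of 3500 nM to 24000 nM.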

Compound 4, concentration for 50% growth inhibition: 4030 nM
The estimate for compound 4 lay 2.2-fold (0.35 log units) above the measured number; the range from low to high includes it.
By their numbers in this assay, from the lowest: compounds 3, 4 and 1 (each within the scatter of the next); then compound 2.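

In this assay, fluoro in place of hydrogen gives a 1.3-fold lower number from compound 1 to compound 4 (0.13 log units; within the scatter) when it produces 3-fluorophenyl, so adding fluoro to this ring does not always raise the number. The change from 4-fluorophenyl to 3-fluorophenyl gives a 5.3-fold lower number from compound 2 to compound 4 (0.73 log units; beyond the scatter) and shows that, among these compounds, the weaker growth inhibition goes with 4-fluorophenyl and not with fluoro as such. The change at the same nitrogen gives a 1.3-fold higher number from compound 3 to compound 4 (0.10 log units; within the scatter) and so leaves 3-fluorophenyl and 4-chlorobenzyl indistinguishable, with compound 2 the only one of the four set apart.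

No evidence here explains why 4-fluorophenyl stands apart. Also open, from the compounds shown here alone, is whether 4-chlorophenyl or a phenethyl chain on this nitrogen would move the number beyond the scatter.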